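The source may report more compounds than this note shows. Statements on the series, on what has been measured and on what is new or still open speak of the compounds shown alone.

Measured compounds:

compound 1 `N#Cc1c(N)nc(SCC(=O)NCO)c(C#N)c1-c1ccc(OCC2CC2)cc1` — 8%
compound 2 `CCOc1ccc(-c2c(C#N)c(N)nc(SCC(N)=O)c2C#N)cc1` — 20%
compound 3 `C=CCOc1ccc(-c2c(C#N)c(N)nc(SCc3ccn[nH]3)c2C#N)cc1` — 13%

All three were tested in an assay on CHO cells for displacement of a labelled ligand from adenosine receptor A3 (Homo sapiens), read by scintillation counting, with a stated time of 120 min, tested at 1 uM; a lower number here means less inhibition, a higher number more inhibition at the concentration tested (going by the name of the read-out). Compound 1 shows the lowest of the three numbers, but the nearest value, that of compound 3, lies within the usual scatter, so no order can be read between those two. Compound 2 stands beyond the scatter above compound 1, and compound 2 is the only one of the three that differs from compound 1 by more than the scatter. Within the data shown here, no pair here differs in a single place, so nothing can be said about what any one change is worth.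

Compound 4 `N#Cc1c(N)nc(SCc2csc(N)n2)c(C#N)c1-c1ccc(OCC2CC2)cc1` has not yet been measured. It differs from compound 1 in one place: 2-amino-1,3-thiazol-4-yl in place of (hydroxymethyl)carbamoyl on a saturated chain carbon bound to a sulfur. Compound 3, which also carries a five-membered aromatic ring on the chain carbon bound to the sulfur, gives 13%, within the scatter of compound 1.

On that basis the step from compound 1 to compound 4 is expected to be small, upward if anything, and likely within the scatter: a number 6 percentage points higher from compound 1 to compound 4 (within the scatter). Compound 4 is therefore estimated at 14%, with a range from 2% to 32%.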

Compound 4, a percentage reported as inhibition, at one concentration (the size of the read-out at that concentration, not a potency): 1%
Compound 4: the middle estimate sits 13 percentage points above what was measured; the whole stated range lies above it.
By their numbers in this assay, from the lowest: compounds 4, 1, 3 and 2 (each within the scatter of the next, the first and the last beyond it).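

Among these compounds, the pair compound 1 and compound 4 gives the first single-place reading: in this assay, 2-amino-1,3-thiazol-4-yl in place of (hydroxymethyl)carbamoyl on a saturated chain carbon bound to a sulfur gives a number 7 percentage points lower from compound 1 to compound 4 (within the scatter). At this position, then, an open amide-bearing group and a five-membered aromatic ring cannot be told apart by this read-out, on the core of compound 1, and compound 4 gives 1% at the one concentration tested. Nothing on hand speaks to the reason for this reading.

Open, on these data alone, is whether any group on this chain carbon moves the number beyond the scatter, for example a carboxylic acid, a primary amine or a longer chain ending in a plain amide. Also open, as far as these compounds go, is what the amino group on the thiazole contributes, which an unsubstituted 1,3-thiazol-4-yl would test.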